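Para Substituent Swap on the Sulfonamide Aniline Series

This account rests on a few compounds, and the source may have more. Where it says the series, first, only, none or still open, it means among the compounds named here.

The series shares a core seen in compound 1 `O=C1NCCN1c1ccc(S(=O)(=O)Nc2ccc(C3CCCCC3)cc2)cc1`, whose partner compounds are compound 2 `Cc1cccc(NS(=O)(=O)c2ccc(N3CCNC3=O)cc2)c1`, compound 3 `Cc1ccc(NS(=O)(=O)c2ccc(N3CCNC3=O)cc2)cc1` and the unmeasured compound 4 `COc1ccc(NS(=O)(=O)c2ccc(N3CCNC3=O)cc2)cc1`. In a functional assay on MCF7 cells (Homo sapiens) for antiproliferative activity, read by sulforhodamine B assay, with a stated time of 48 h (a lower number here means a stronger inhibitor, a higher number a weaker inhibitor), compound 1 reaches only the limit of the measurement, namely > 1000 nM, a ceiling rather than a number. Compound 2 gives 190 nM in this assay, and compound 3 gives 610 nM. The change from compound 1 to compound 4 is methoxy in place of cyclohexyl on an aromatic carbon. The closest measured step is the related replacement in an at least 1.6-fold lower number from compound 1 to compound 3 (0.21 log units; that floor lies within the scatter), where a small group likewise took the place of the cyclohexyl. The step of a 3.2-fold higher number from compound 2 to compound 3 (0.51 log units; beyond the scatter) concerns the position of the methyl rather than its nature and bears only indirectly. He therefore expects a downward step of roughly the size seen for compound 3, so that compound 4 is estimated at 600 nM, with a range from 200 nM to 2000 nM, an expected step of an at least 1.6-fold lower number from compound 1 to compound 4 (0.22 log units; that floor lies within the scatter).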

Compound 4, half-maximal inhibitory concentration: > 1000 nM
Compound 4: no number, only a limit (the forecaster's own chance of this, stated with the estimate: 25%); middle value at least 1.6-fold (0.22 log units) from the limit.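

In this assay, methoxy in place of methyl on this aromatic carbon gives an at least 1.6-fold higher number from compound 3 to compound 4 (0.21 log units; that floor lies within the scatter), so a small group here does not ensure a measured value, though this floor alone does not separate methoxy from methyl. The firmer reading comes from the comparison with the methyl compound that has the other substitution pattern, which shows an at least 5.2-fold higher number from compound 2 to compound 4 (0.72 log units; beyond the scatter). The step from cyclohexyl to methoxy cannot be read, since both compounds end at the same ceiling: the limit of > 1000 nM in this assay, at which 2 of the 4 values shown sit.

The compounds shown leave open how far above that limit compound 4 lies, and whether methoxy would fare better at the position the methyl holds in compound 2. They also leave open whether an amine, a hydroxyl or a fluorine at the position of the methoxy would give a measurable value.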